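A few compounds are considered here, and "the series" means these few. Any claim that something is new, unique, unknown or untested is made for them only; others in the source may bear on it.

Working notes on the series.

Compound 1 `O=C(NCN1CCC(c2cccc[n+]2[O-])CC1)c1ccccc1` gives, in a functional assay on HEK293 cells for agonist activity at D(4) dopamine receptor (Homo sapiens), read by FLIPR (on this read-out higher numbers stand for larger maximal responses and lower numbers for smaller maximal responses), a maximal response of 63%. Compound 2 `O=C(CN1CCC(c2cccc[n+]2[O-])CC1)Nc1ccc(F)cc1F`, which carries the same core but a different link to the aryl group, gives in this assay a response of 74%. Among the two numbers available, compound 2 stands highest, and its gap to compound 1 lies beyond the usual scatter of repeated measurements. Among the measured compounds shown here, no pair that differs in only one place has been measured so far, so no single-step reading exists yet.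

The next compound, compound 3 `O=C(CN1CCC(c2cccc[n+]2[O-])CC1)Nc1ccc(F)cc1`, differs from compound 2 by one change: hydrogen in place of fluoro on an aromatic carbon. The effect of taking away this fluoro has not been seen anywhere in the series, so the expectation rests only on compound 2 and its value of 74%. A small step in this assay is expected, a number 6 percentage points lower from compound 2 to compound 3 (within the scatter), either direction possible and most likely not beyond the scatter. Compound 3 is therefore estimated at 68% in this assay, with a range from 54% to 82%.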

Compound 3, largest response reached (reported as efficacy), in percent of the reference or control that the assay uses: 71%
The estimate for compound 3 lay 3 percentage points below the measured number; low and high end bracket the measured number.
By their numbers in this assay, from the lowest: compounds 1, 3 and 2 (each within the scatter of the next, the first and the last beyond it).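

In this assay the series now has its first pair that differs in one place, and the 2,4-difluorophenyl to 4-fluorophenyl change gives a number 3 percentage points lower from compound 2 to compound 3 (within the scatter). At this aromatic carbon, ortho to a large group and meta to a fluoro group, fluoro and hydrogen therefore cannot be told apart by maximal response, so compound 3 and compound 2 read as equivalent here, a statement that rests on this single pair and on this one read-out. Nothing available bears on the reason for this outcome.

The compounds shown leave open whether any other group at this carbon, such as chloro, methoxy or trifluoromethyl, would move the response beyond the scatter, and whether the fluoro group that remains in compound 3 matters, which a plain phenyl would test. Also open, going by these compounds, is whether the same exchange of hydrogen for fluoro would read alike on the different link to the aryl group carried by compound 1.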